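The compounds below may be only part of what the source reports. "The series", "measured", "known", "first", "only" and "open" are said of these compounds alone.

In a functional assay on A549 cells (Homo sapiens) for cytotoxicity, read by MTT assay, with a stated time of 48 h (on this read-out lower numbers stand for stronger inhibition and higher numbers for weaker inhibition), compound 3 `CC(C)(C)c1ccc(Cn2cc(COc3ccc4c(=O)ccoc4c3)nn2)cc1` gives only a limit of the assay, > 100000 nM, and not a number. Compound 2 `N#Cc1ccc(Cn2cc(COc3ccc4c(=O)ccoc4c3)nn2)cc1` likewise returns a limit, > 100000 nM. Compound 1 `Cc1cccc(Cn2cc(COc3ccc4c(=O)ccoc4c3)nn2)c1` gives 20300 nM, so the step of an at least 4.9-fold higher number from compound 1 to compound 2 (0.69 log units; beyond the scatter) is the only one that can be sized. The step that the two limits leave unreadable from compound 2 to compound 3 cannot be read because both of its ends sit at the limit (the limit of > 100000 nM in this assay, at which 2 of the 3 values shown sit). Compound 4 `COc1ccc(Cn2cc(COc3ccc4c(=O)ccoc4c3)nn2)cc1` differs from compound 3 by methoxy in place of tert-butyl on an aromatic carbon. Among the measured compounds shown here, no measured step shows methoxy on an aromatic carbon, and the one step at that carbon is unreadable, so no direction beyond the scatter can be expected. Compound 4 is therefore expected to stay near the limit, a step of an at least 1.2-fold lower number from compound 3 to compound 4 (0.09 log units; that floor lies within the scatter). The estimate for compound 4 is 80000 nM, with a range from 20000 nM to 300000 nM.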

Compound 4, half-maximal inhibitory concentration: 16500 nM
For compound 4 the middle estimate is 4.8-fold (0.69 log units) above the measured one; measured number below the stated range.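

In this assay, among the compounds shown here, methoxy is the first group on this aromatic carbon to give a readable number, with an at least 6.0-fold lower number from compound 3 to compound 4 (0.78 log units; beyond the scatter) and an at least 6.0-fold lower number from compound 2 to compound 4 (0.78 log units; beyond the scatter). This shows that the group at this carbon matters, which the earlier results could not show on their own: the limit of > 100000 nM in this assay, at which 2 of the 4 values shown sit. The 4-methoxyphenyl and 3-methylphenyl groups cannot be told apart here, with a 1.2-fold lower number from compound 1 to compound 4 (0.09 log units; within the scatter).

The compounds shown leave open whether an amine or a carboxylic acid on this carbon would also give a readable number. They also leave open whether methoxy would give the same result elsewhere on the ring.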